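Five-membered heteroaryl swap on the shared core

The source may report more compounds than this note shows. Statements on the series, on what has been measured and on what is new or still open speak of the compounds shown alone.

Measured so far:
compound 1 `CC(C)OC(=O)C1=C(C(F)(F)F)NC(=O)NC1c1ccsc1`: 23%
compound 2 `CC(C)OC(=O)C1=C(C(F)(F)F)NC(=O)NC1c1ccoc1`: 27%
compound 3 `CC(C)OC(=O)C1=C(C(F)(F)F)NC(=O)NC1c1ccco1`: 11%

In an assay on cells for displacement of a labelled ligand from adenosine receptor A1 (Homo sapiens), read by radioligand binding, with a stated time of 60 min, tested at 1 uM (a higher number here means more inhibition at the concentration tested (going by the name of the read-out), a lower number less inhibition), compound 3 gives 11% and stands lowest of the three numbers. One step reaching it is a number 12 percentage points lower from compound 1 to compound 3 (beyond the scatter), and the other is a number 16 percentage points lower from compound 2 to compound 3 (beyond the scatter), both beyond the scatter. Between compound 1 and compound 2 the step is a number 4 percentage points higher from compound 1 to compound 2 (within the scatter), within the scatter.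

Compound 4 `CC(C)OC(=O)C1=C(C(F)(F)F)NC(=O)NC1c1cccs1` has not been measured. It differs from compound 3 as follows: thiophen-2-yl in place of furan-2-yl on a saturated ring carbon. Within the data shown here, the only measured step that exchanges the ring hetero atom is the one from compound 1 to compound 2, a number 4 percentage points higher from compound 1 to compound 2 (within the scatter), which lies within the scatter; the steps to compound 3 change the point of attachment, not the hetero atom, and so bear less directly on this change. Therefore no step beyond the scatter is expected in this assay, and the expected step from compound 3 to compound 4 is a number 3 percentage points higher from compound 3 to compound 4 (within the scatter). Compound 4 is estimated at 14%, in a range from 3% to 27%.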

Compound 4, a percentage reported as inhibition, at one concentration (the size of the read-out at that concentration, not a potency): 8%
Estimate against measurement, compound 4: 6 percentage points above; the range from low to high includes it.
By their numbers in this assay, from the lowest: compounds 4 and 3 (each within the scatter of the next); then compounds 1 and 2 (each within the scatter of the next).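

The step of a number 3 percentage points lower from compound 3 to compound 4 (within the scatter) shows that in this assay exchanging the ring hetero atom leaves the number within the scatter with attachment through the 2-position as well, as it did with the 3-yl pair. The steps of a number 15 percentage points lower from compound 1 to compound 4 (beyond the scatter) and a number 19 percentage points lower from compound 2 to compound 4 (beyond the scatter) show that thiophen-2-yl, like furan-2-yl, gives a lower number than the 3-yl groups, so among these four compounds the point of attachment on the saturated ring carbon separates the numbers and the hetero atom does not, with no compound going against this. Nothing on hand gives a reason for this difference between attachment points.

Still open, as far as these compounds go, is whether a phenyl ring or a pyridine at this position would follow the same pattern. Also open, from the compounds shown here alone, is whether an amine or a carboxylic acid on the ring would raise the number above those of compound 1 and compound 2.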